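This account rests on a few compounds, and the source may have more. Where it says the series, first, only, none or still open, it means among the compounds named here.

Of the compounds shown here, three of one series have been measured in a functional assay on SK-MEL-2 cells (Homo sapiens) for cytotoxicity, read by sulforhodamine B assay, with a stated time of 48 h; a higher number here means a weaker inhibitor of growth, a lower number a stronger inhibitor of growth. Compound 1 `ClCc1cccc(Cn2cnc3ncnc(Cl)c32)c1` gives 22900 nM. Compound 2 `ClCc1ccc(Cn2cnc3nc(Cl)nc(Cl)c32)cc1` gives 2690 nM, and compound 3 `ClCc1cccc(Cn2cnc3nc(Cl)nc(Cl)c32)c1` gives 3710 nM. Compound 2 and compound 3 have the same atoms joined differently; how their cores differ is not broken down here, and their two values lie within the scatter of each other. Compound 1 stands apart from both: from compound 3 to compound 1 the measurement rises by a 6.2-fold higher number from compound 3 to compound 1 (0.79 log units; beyond the scatter), a step beyond the scatter, and the change behind it is hydrogen in place of chloro on an aromatic carbon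

A fourth member, compound 4 `ClCc1ccc(Cn2cnc3ncnc(Cl)c32)cc1`, has not yet been measured in this assay. It differs from compound 2 by hydrogen in place of chloro on an aromatic carbon

Within the data shown here, this is the same change, at the same kind of place, as the one from compound 3 to compound 1. Among the measured compounds shown here, with only that single measured instance to go on, the expectation for compound 4 rests on it alone. Compound 4 is therefore expected to give a higher number than compound 2, with an estimated step of a 5.6-fold higher number from compound 2 to compound 4 (0.75 log units; beyond the scatter), because the measured step of a 6.2-fold higher number from compound 3 to compound 1 (0.79 log units; beyond the scatter) was of modest size and beyond the scatter. On that basis compound 4 is estimated at 15000 nM in this assay, with a plausible range from 5000 nM to 45000 nM.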

Compound 4, concentration for total growth inhibition: > 100000 nM
Compound 4 gave a limit, no number; the forecaster's own chance of this, stated with the estimate: 10%; middle value at least 6.6-fold (0.82 log units) from the limit.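

In this assay, from the compounds shown here alone, hydrogen in place of chloro on an aromatic carbon between two ring nitrogen atoms gives an at least 37-fold higher number from compound 2 to compound 4 (1.57 log units; beyond the scatter), so the direction seen on the earlier pair carries over to this one, but the size does not: the same change on two cores in this assay, a 6.2-fold higher number (0.79 log units; beyond the scatter) from compound 3 to compound 1 and an at least 37-fold higher number (1.57 log units; beyond the scatter) from compound 2 to compound 4, at least 6.0-fold (0.77 log units) apart, beyond the scatter of two such steps The value of compound 4, > 100000 nM, is a limit of the assay and not a number, so the full size of this step remains unknown: the limit of > 100000 nM in this assay, at which 1 of the 4 values shown sits. These two pairs show that the same change can give steps of clearly different size on two closely related cores, but they do not show which difference between the cores goes with the gap, nor how the change would behave on any further core.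

The compounds shown carry only chloro or hydrogen at this carbon, which leaves open how an amine, a methoxy group or a thiol there would read in this assay. Going by these compounds, all of them also keep a chloromethyl group, so it remains open whether the steps would hold with a plain methyl or a hydroxymethyl group in its place.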